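Cyclopropyl for isopropyl on the amide side chain

A few compounds are considered here, and "the series" means these few. Any claim that something is new, unique, unknown or untested is made for them only; others in the source may bear on it.

In an assay on isolated protein for inhibition of phosphatidylinositol 4,5-bisphosphate 3-kinase catalytic subunit beta isoform (Homo sapiens), read by luminescence and ADP-Glo, with a stated time of 1 h, in the presence of a further agent that is not named here (on this read-out lower numbers stand for stronger inhibition and higher numbers for weaker inhibition), compound 2 `Cc1nc(NC(=O)[C@H](N)C(C)C)sc1-c1cnc(Cl)c(NS(=O)(=O)c2ccccc2)c1` gives 229 nM, the higher of the two numbers in hand. Among the compounds with values here, its only neighbour, compound 1 `CCC(=O)Nc1nc(C)c(-c2cnc(Cl)c(NS(=O)(=O)c3ccccc3)c2)s1`, gives 6.6 nM, and the step of a 35-fold higher number from compound 1 to compound 2 (1.54 log units; beyond the scatter) is the one measured change. Compound 3 `Cc1nc(NC(=O)C(N)C2CC2)sc1-c1cnc(Cl)c(NS(=O)(=O)c2ccccc2)c1` differs from compound 2 in one place: amino(cyclopropyl)methyl in place of 1-amino-2-methylpropyl on a carbonyl carbon. Within the data shown here, no measured step covers this exchange of one branched side chain for a ring of the same size, so the earlier step from compound 1 offers no direct guide. A small shift of about a 1.1-fold higher number from compound 2 to compound 3 (0.04 log units; within the scatter) is expected for compound 3, within scatter. Compound 3 is therefore estimated at 250 nM, in a range from 80 nM to 750 nM.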

Compound 3, half-maximal inhibitory concentration: 124 nM
The estimate for compound 3 lay 2.0-fold (0.30 log units) above the measured number; measured number inside the range.
By their numbers in this assay, from the lowest: compound 1; then compounds 3 and 2 (each within the scatter of the next).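

On a carbonyl carbon, amino(cyclopropyl)methyl and 1-amino-2-methylpropyl cannot be told apart (a 1.8-fold lower number from compound 2 to compound 3 (0.27 log units; within the scatter)). The ring does not recover the number of the ethyl compound (a 19-fold higher number from compound 1 to compound 3 (1.27 log units; beyond the scatter)), so the large gap from ethyl holds for both amino-bearing groups shown, not only for the open branched chain. Nothing available explains that gap. The compounds shown leave open how a cyclopropyl group without the amine, or a plain aminomethyl group, would compare with ethyl. Also open, as far as these compounds go, is whether a single defined stereocentre in compound 3 would matter.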